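Swapping the Aryl Group on the Exocyclic Double Bond

This account rests on a few compounds, and the source may have more. Where it says the series, first, only, none or still open, it means among the compounds named here.

Three compounds sharing one core differ only in the aromatic group carried on a double-bonded chain carbon bound to a double-bonded ring carbon. Compound 1 `Cc1cccc(/C=C2/SC(N3CCC[C@H]3C(=O)Nc3ccc4ncnc(Nc5cccc(Cl)c5)c4c3)=NC2=O)n1` gives 8500 nM in a functional assay on A549 cells (Homo sapiens) for antiproliferative activity, read by MTT assay; a higher number here means a weaker inhibitor, a lower number a stronger inhibitor. Compound 2 `O=C1N=C(N2CCC[C@H]2C(=O)Nc2ccc3ncnc(Nc4cccc(Cl)c4)c3c2)S/C1=C/c1cccnc1` gives 10400 nM, and compound 3 `O=C1N=C(N2CCC[C@H]2C(=O)Nc2ccc3ncnc(Nc4cccc(Cl)c4)c3c2)S/C1=C/c1ccc(-c2ccccc2)cc1` gives 24200 nM, the highest of the three numbers. The step of a 2.8-fold higher number from compound 1 to compound 3 (0.45 log units; beyond the scatter) and the step of a 2.3-fold higher number from compound 2 to compound 3 (0.37 log units; beyond the scatter) both run toward higher numbers when 4-phenylphenyl enters in place of a single six-membered ring, while a 1.2-fold higher number from compound 1 to compound 2 (0.09 log units; within the scatter) stays within the scatter.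

Compound 4 `O=C1N=C(N2CCC[C@H]2C(=O)Nc2ccc3ncnc(Nc4cccc(Cl)c4)c3c2)S/C1=C/c1ccccc1Br` carries 2-bromophenyl in place of 4-phenylphenyl on a double-bonded chain carbon bound to a double-bonded ring carbon. This returns to a single six-membered ring, so the two steps to compound 3 are the ones that bear on it, and they suggest the number should come back down. For compound 4 a step of a 2.2-fold lower number from compound 3 to compound 4 (0.34 log units; beyond the scatter) is expected in this assay. Compound 4 is therefore estimated at 11000 nM, with a range from 5000 nM to 25000 nM.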

Compound 4, half-maximal inhibitory concentration: > 50000 nM
Compound 4: only a limit was reported; the forecaster's own chance of this, stated with the estimate: 10%; middle value at least 4.5-fold (0.65 log units) from the limit.
By their numbers in this assay, from the lowest: compounds 1 and 2 (each within the scatter of the next); then compound 3. At a limit, above all of these: compound 4.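

Compound 4 gives > 50000 nM in this assay and that value is a limit of the assay. With fewer heavy atoms and a single ring, 2-bromophenyl in place of 4-phenylphenyl still gives an at least 2.0-fold higher number from compound 3 to compound 4 (0.31 log units; beyond the scatter) at this carbon, so heavy-atom count alone does not order these groups. Single-ring groups also part here: pyridin-3-yl and 6-methylpyridin-2-yl stay within the scatter of each other, while 2-bromophenyl gives an at least 4.8-fold higher number from compound 2 to compound 4 (0.68 log units; beyond the scatter) and an at least 5.8-fold higher number from compound 1 to compound 4 (0.76 log units; beyond the scatter) on the same swap.

From the compounds shown here alone, the true value of compound 4 remains unknown, so these steps have only a lower bound. Going by these compounds, whether the bromine itself or its place on the ring matters stays open, and a plain phenyl, a 4-bromophenyl or a phenyl bearing an amine at this carbon would help to separate the two.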